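Trading compound 3's aryl group for 3-fluoro-2-methoxyphenyl

This account rests on a few compounds, and the source may have more. Where it says the series, first, only, none or still open, it means among the compounds named here.

Of the compounds shown here, three sharing one core have been measured in a functional assay on HOS-TE85 cells (Homo sapiens) for inhibition, read by CCK-8 assay, with a stated time of 72 h; a lower number here means a stronger inhibitor, a higher number a weaker inhibitor. Compound 1 `COc1ccc(C)cc1N1C(=O)CSC1c1cccc(C(=O)NCCCCc2ccccc2)c1` gives 300 nM, compound 2 `Cc1cccc(N2C(=O)CSC2c2cccc(C(=O)NCCCCc3ccccc3)c2)c1` gives 93.2 nM and compound 3 `CC(F)(F)c1cccc(N2C(=O)CSC2c2cccc(C(=O)NCCCCc3ccccc3)c2)c1` gives 29.1 nM. Compound 3 therefore has the lowest number of the three and is the most potent, with its gaps to both others beyond the usual scatter.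

Compound 4 `COc1c(F)cccc1N1C(=O)CSC1c1cccc(C(=O)NCCCCc2ccccc2)c1` alters the group on the amide-type nitrogen in a ring: a group of 9 heavy atoms (7 carbon, 1 oxygen, 1 fluorine; one six-membered aromatic ring of carbon only) in place of a group of 10 heavy atoms (8 carbon, 2 fluorine; one six-membered aromatic ring of carbon only), on an amide-type nitrogen in a ring. It loses the 1,1-difluoroethyl and gains a methoxy on 3-fluoro-2-methoxyphenyl. Two measured steps speak to this. The first is a 3.2-fold lower number from compound 2 to compound 3 (0.51 log units; beyond the scatter), seen with 1,1-difluoroethyl in place of methyl. The second is a 3.2-fold lower number from compound 1 to compound 2 (0.51 log units; beyond the scatter), seen with hydrogen in place of methoxy. Together they span a 10-fold lower number from compound 1 to compound 3 (1.01 log units; beyond the scatter), and compound 1, the only measured methoxy compound, sits highest. For the measured compounds named here, no measured compound carries a fluorine directly on the aromatic ring, so that part of the change remains untested.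

A clear rise in the number is therefore expected, approaching the size of the largest measured step. The estimate means a 6.9-fold higher number from compound 3 to compound 4 (0.84 log units; beyond the scatter). For compound 4 the expected value is 200 nM, with an estimated range of 70 nM to 550 nM.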

Compound 4, half-maximal inhibitory concentration: 26.2 nM
The estimate for compound 4 lay 7.6-fold (0.88 log units) above the measured number; the whole stated range lies above it.
By their numbers in this assay, from the lowest: compounds 4 and 3 (each within the scatter of the next); then compound 2; then compound 1.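

In this assay the 3-fluoro-2-methoxyphenyl group on the amide-type nitrogen matches the aryl group of compound 3, with a 1.1-fold lower number from compound 3 to compound 4 (0.05 log units; within the scatter) and so the 1,1-difluoroethyl group is not needed for a number at this level among these compounds. For the compounds shown here, a methoxy group also no longer goes with the highest number: compound 1 and compound 4 both carry one, yet the aryl change gives an 11-fold lower number from compound 1 to compound 4 (1.06 log units; beyond the scatter) and the comparison with the methyl-bearing aryl group gives a 3.6-fold lower number from compound 2 to compound 4 (0.55 log units; beyond the scatter) while compound 1 remains the one methoxy compound that goes against any link between methoxy and a low number. Nothing available here explains why these two aryl groups give numbers within the scatter of each other.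

The compounds shown leave open what the fluorine and the methoxy of 3-fluoro-2-methoxyphenyl each contribute on their own, since the two always arrive together in compound 4. They also leave open what a chlorine, a nitrile or an amine would give on this aryl ring, and whether the four-carbon chain ending in phenyl on the other amide tolerates change alongside this group.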